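Shortening a nitrile chain on a flat cytotoxicity series

The source may hold more compounds than are shown below. What is called first, only, known or untested is meant among the compounds shown, and "the series" means these compounds.

Compound 1 `COc1ccc2cc(-c3ccccc3)c(O)nc2c1`: 10000 nM
Compound 2 `COc1cc(OC)c2cc(-c3ccc(OCc4ccccc4)cc3)c(O)nc2c1`: 10000 nM
Compound 3 `COc1ccc(-c2cc3c(OC)cc(OC)cc3n(CCCC#N)c2=O)cc1`: 10000 nM

In a functional assay on T47D cells (Homo sapiens) for cytotoxicity, read by colorimetric assay and MTT assay (a higher number here means a weaker inhibitor, a lower number a stronger inhibitor), compound 3 gives 10000 nM, level with compound 1 and compound 2 at the digits shown. Compound 4 `COc1ccc(-c2cc3c(OC)cc(OC)cc3n(CCC#N)c2=O)cc1` changes compound 3 in one place: cyano in place of cyanomethyl on a saturated chain carbon, two bonds along the chain from an aromatic nitrogen. Put another way, 3-cyanopropyl becomes 2-cyanoethyl. Going by the values given here, no measured pair shows what this change does. Among the compounds with values here, the only guide is that compound 3 stands at 10000 nM, so no shift beyond the scatter is expected. The estimated step is no change at the digits printed from compound 3 to compound 4 (within the scatter). Compound 4 is expected at 10000 nM, with an estimated range of 5000 nM to 20000 nM.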

Compound 4, half-maximal inhibitory concentration: 10000 nM
Compound 4: middle estimate and measured number agree at the digits printed; low and high end bracket the measured number.
By their numbers in this assay, from the lowest: compounds 1, 2, 3 and 4 (each within the scatter of the next).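

In this assay, going by these compounds alone, going from 3-cyanopropyl to 2-cyanoethyl gives no change at the digits printed from compound 3 to compound 4 (within the scatter), the only measured pair at this position. It shows that, in this one pair, the shorter nitrile chain reads the same as the longer one. No supporting measurement on hand bears on this result.

Still open, on these data alone, is how other groups at this place would read, such as an amine, a carboxylic acid or a longer chain. As far as these compounds go, whether any change here can move the number also remains open.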